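The source may hold more compounds than are shown below. What is called first, only, known or untested is meant among the compounds shown, and "the series" means these compounds.

The three measured compounds share one core and differ only in two groups attached to it. Compound 1 `Oc1cccc(-c2nc(N3CCCCC3)c3nc[nH]c3n2)c1` carries a piperidin-1-yl group and a 3-hydroxyphenyl group. In an assay on cells for displacement of a labelled ligand from adenosine receptor A3 (Homo sapiens), read by scintillation counting and radioligand binding, with a stated time of 180 min, tested at 10 uM (a lower number here means less inhibition, a higher number more inhibition at the concentration tested (going by the name of the read-out)), compound 1 reaches > 80%, which is a limit of the assay and not a number. Compound 2 `CN1CCN(c2nc(-c3cccc(O)c3)nc3[nH]cnc23)CC1` gives > 80% in this assay, again a limit. Compound 3 `Oc1ccc(-c2nc(N3CCCCC3)c3nc[nH]c3n2)cc1` gives > 80% in this assay, also a limit. The change from compound 1 to compound 2 is 4-methylpiperazin-1-yl in place of piperidin-1-yl on an aromatic carbon, and its size is a step that the two limits leave unreadable from compound 1 to compound 2 because of the limit of > 80% in this assay, at which 3 of the 3 values shown sit. The cores of compound 3 and compound 1 differ by 4-hydroxyphenyl in place of 3-hydroxyphenyl on an aromatic carbon.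

Compound 4 `CN1CCN(c2nc(-c3ccc(O)cc3)nc3[nH]cnc23)CC1` has not been measured. It differs from compound 3 by 4-methylpiperazin-1-yl in place of piperidin-1-yl on an aromatic carbon, the same kind of change as from compound 1 to compound 2, though the place is meta to a 4-hydroxyphenyl group rather than meta to a 3-hydroxyphenyl group. For compound 4 the expected step is a step that the limit leaves unreadable from compound 3 to compound 4, resting on the unreadable earlier step that the two limits leave unreadable from compound 1 to compound 2. The estimate for compound 4 is 85%, expected to fall between 60% and 100%.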

Compound 4, a percentage reported as inhibition, at one concentration (the size of the read-out at that concentration, not a potency): 48%
Compound 4: middle estimate off by 37 percentage points, on the high side, outside the stated range (below it).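

In this assay, 4-methylpiperazin-1-yl in place of piperidin-1-yl gives a number at least 32 percentage points lower from compound 3 to compound 4 (beyond the scatter), and 4-hydroxyphenyl in place of 3-hydroxyphenyl gives a number at least 32 percentage points lower from compound 2 to compound 4 (beyond the scatter), so each change has a large effect when the other group is already present. The matching steps among compound 1, compound 2 and compound 3 cannot be read, because those values are limits of the assay and not numbers: the limit of > 80% in this assay, at which 3 of the 4 values shown sit. This shows that the swap to 4-methylpiperazin-1-yl does not leave inhibition intact alongside the 4-hydroxyphenyl group, but it does not show whether the same swap alongside the 3-hydroxyphenyl group lowers inhibition less, equally or not at all.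

The compounds shown leave open whether the drop for compound 4 follows from the second ring nitrogen or from its methyl group, which piperazin-1-yl or morpholin-4-yl in the same place could separate. They also leave open whether a 4-methoxyphenyl group would behave as the 4-hydroxyphenyl group does.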